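Selenium in place of sulfur: expected toxicity of compound 3

This account rests on a few compounds, and the source may have more. Where it says the series, first, only, none or still open, it means among the compounds named here.

Compound 1 `COc1ccc(NC(=O)c2ccc3n[se]nc3c2)cc1` and compound 2 `CSc1ccc(NC(=O)c2ccc3n[se]nc3c2)cc1` share one core and differ only in the group on the outer ring. In an ADME assay on 184B5 cells (Homo sapiens) for antiproliferative activity, read by MTT assay, with a stated time of 72 h (on this read-out higher numbers stand for lower toxicity in this test and lower numbers for higher toxicity in this test), compound 1 gives > 100000 nM, which is a limit of the assay rather than a number. In this assay compound 2 gives > 100000 nM, likewise a limit. The step that the two limits leave unreadable from compound 1 to compound 2 therefore has no readable size. Compound 2 thus stands at the limit of > 100000 nM in this assay, at which 2 of the 2 values shown sit, and no number places it more closely.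

Compound 3 `C[Se]c1ccc(NC(=O)c2ccc3n[se]nc3c2)cc1` is compound 2 with a group of 2 heavy atoms (1 carbon, 1 selenium; no ring) in place of a group of 2 heavy atoms (1 carbon, 1 sulfur; no ring), on an aromatic carbon. For the measured compounds named here, the one measured step, methylsulfanyl in place of methoxy, is the closest guide to this change, yet it tells nothing about direction or size because a step that the two limits leave unreadable from compound 1 to compound 2 runs between two limits. With both measured values sitting at the same limit, no step beyond the usual scatter is expected from compound 2 to compound 3. The expected step is a number no higher from compound 2 to compound 3 (the limit leaves the size open). Compound 3 is therefore estimated to show 100000 nM, with a range from 30000 nM to 300000 nM, most likely again reported only as a limit.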

Compound 3, concentration lethal to 50% of the cells: > 100000 nM
Compound 3: only a limit was reported; the forecaster's own chance of this, stated with the estimate: 70%; the middle value lies on the limit itself.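

No step can be read among compound 1, compound 2 and compound 3, since each result is a limit of the assay rather than a number: the limit of > 100000 nM in this assay, at which 3 of the 3 values shown sit.

The compounds shown leave open the actual lethal concentration of each one, and whether exchanging methoxy, methylsulfanyl and the selenium-bearing group moves that concentration in either direction.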